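This account rests on a few compounds, and the source may have more. Where it says the series, first, only, none or still open, it means among the compounds named here.

Compound 1 `COc1ccc(C(=O)/C=C/c2cc3ccccc3[nH]c2=O)cc1` and compound 2 `O=C(/C=C/c1cc2ccccc2[nH]c1=O)c1ccc(O)cc1` share one core and differ at a single oxygen. In an ADME assay on UACC-62 cells (Homo sapiens) for cytotoxicity, read by sulforhodamine B assay, with a stated time of 24 h (on this read-out higher numbers stand for lower toxicity in this test and lower numbers for higher toxicity in this test), compound 1 gives 60200 nM, and in this assay compound 2 gives 39600 nM, the lowest of the two numbers, yet separated from compound 1 only by a 1.5-fold lower number from compound 1 to compound 2 (0.18 log units; within the scatter). Compound 3 `O=C(/C=C/c1cc2ccccc2[nH]c1=O)c1ccc(Cl)cc1` carries chloro in place of hydroxy on an aromatic carbon. For the measured compounds named here, the sole measured step touches the same position and stayed within the scatter, so the change to compound 3 is expected to give a 1.1-fold lower number from compound 2 to compound 3 (0.05 log units; within the scatter), nothing beyond the scatter. Compound 3 is therefore estimated at 35000 nM in this assay, between 12000 nM and 100000 nM.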

Compound 3, concentration lethal to 50% of the cells: > 100000 nM
Compound 3 ended at the assay's limit; the forecaster's own chance of this, stated with the estimate: 10%; middle value at least 2.8-fold (0.45 log units) away from the limit.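

Chloro in place of hydroxy gives an at least 2.5-fold higher number from compound 2 to compound 3 (0.40 log units; beyond the scatter), so a change at this position can move the number beyond the scatter, which the first pair did not show. Chloro in place of methoxy gives an at least 1.6-fold higher number from compound 1 to compound 3 (0.22 log units; that floor lies within the scatter), so a real gap between those two is not established. The result for compound 3 is a limit of the assay, not a number: the limit of > 100000 nM in this assay, at which 1 of the 3 values shown sits.

On these data alone, the true size of both steps therefore stays unknown. Also open, as far as these compounds go, is how an amine, a carboxylic acid or a longer chain such as ethoxy would read at this position.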